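Ethenyl Bridge in the Benzamide Arm and Antiproliferative Effect

The compounds below may be only part of what the source reports. "The series", "measured", "known", "first", "only" and "open" are said of these compounds alone.

Compound 1 `Cc1ccc(Nc2nc(Cl)nc3c2ncn3Cc2ccc(C(=O)Nc3ccccc3N)cc2)cc1` and compound 2 `Cc1ccc(Nc2nc(Cl)nc3c2ncn3Cc2ccc(/C=C/C(=O)Nc3ccccc3N)cc2)cc1` share one core and differ in a single place. In a functional assay on HCT-116 cells (Homo sapiens) for antiproliferative activity, read by CCK-8 assay, with a stated time of 72 h, tested at 8 uM (on this read-out higher numbers stand for a stronger effect at the one concentration tested and lower numbers for a weaker effect), compound 1 gives 81.5%, and compound 2 gives 15%. The step is a number 66.5 percentage points lower from compound 1 to compound 2 (beyond the scatter); the change behind it is 2-((2-aminophenyl)carbamoyl)ethenyl in place of (2-aminophenyl)carbamoyl on an aromatic carbon.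

Compound 3 `CC(C)n1cnc2c(Nc3cccc(Cl)c3)nc(NCOCc3ccc(C(=O)Nc4ccccc4N)cc3)nc21` is built on a different core; the difference between the two cores is not broken down here. In this assay compound 3 gives 63.4%, which stands second of the three numbers measured.

Compound 4 `CC(C)n1cnc2c(Nc3cccc(Cl)c3)nc(NCOCc3ccc(/C=C/C(=O)Nc4ccccc4N)cc3)nc21` carries the same change relative to compound 3 that compound 2 carries relative to compound 1, namely (2-((2-aminophenyl)carbamoyl)ethenyl in place of (2-aminophenyl)carbamoyl on an aromatic carbon). Because the earlier step was a number 66.5 percentage points lower from compound 1 to compound 2 (beyond the scatter), a step of comparable direction is expected here, limited by the floor of the read-out: the estimated step is a number 51.4 percentage points lower from compound 3 to compound 4 (beyond the scatter). Whether the second core damps or sharpens this effect cannot be told from these three compounds. On this basis compound 4 is estimated to give 12% in this assay, with a range from 0% to 38%.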

Compound 4, a percentage reported as inhibition, at one concentration (the size of the read-out at that concentration, not a potency): 27.9%
Beside the measured number, compound 4's estimate is 15.9 percentage points below it, and the stated range covers the measured number.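

In this assay, 2-((2-aminophenyl)carbamoyl)ethenyl in place of (2-aminophenyl)carbamoyl again brings a fall, a number 35.5 percentage points lower from compound 3 to compound 4 (beyond the scatter), so the direction of the step is the same on both cores shown. The size of the step does not carry over from one core to the other: the same change on two cores in this assay, a number 66.5 percentage points lower (beyond the scatter) from compound 1 to compound 2 and a number 35.5 percentage points lower (beyond the scatter) from compound 3 to compound 4, 31 percentage points apart, beyond the scatter of two such steps

With a single pair on each core and one concentration in one cell line, these results do not show why the size differs, nor whether the same direction would appear on any further core or say anything about potency.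

The compounds shown leave open whether the fall follows from the double bond itself or from the longer link, a question that a saturated chain in place of the ethenyl unit would address. They also leave open whether the step would look the same with another end group, such as a hydroxamic acid, in place of the 2-aminophenyl amide.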